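Compound 3 to compound 4: a larger group at the limit

A few compounds are considered here, and "the series" means these few. Any claim that something is new, unique, unknown or untested is made for them only; others in the source may bear on it.

Compound 1 `COc1ccc([C@H]2CC(=O)N(c3cccc(C#N)c3)C2)cc1OC1CCCC1` gives > 10000 nM (a limit)
Compound 2 `COc1ccc([C@H]2CC(=O)N(c3cccc(S(C)(=O)=O)c3)C2)cc1OC1CCCC1` gives > 10000 nM (a limit)
Compound 3 `COc1ccc([C@H]2CC(=O)N(c3cccc(NCc4ccoc4)c3)C2)cc1OC1CCCC1` gives > 10000 nM (a limit)

In a functional assay on HEK293 cells (Homo sapiens) for cytotoxicity (a lower number here means that less compound is tolerated, a higher number that more compound is tolerated), compound 3 gives > 10000 nM (a limit of the assay, not a number). It therefore has no exact position in the series, and the same holds for compound 1 and compound 2 (the limit of > 10000 nM in this assay, at which 3 of the 3 values shown sit).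

Compound 4 `COc1ccc([C@H]2CC(=O)N(c3cccc(NCCCc4ccccc4)c3)C2)cc1OC1CCCC1` carries phenethyl in place of furan-3-yl on a saturated chain carbon bound to a nitrogen on an aromatic ring, so that (furan-3-yl)methyl becomes 3-phenylpropyl (phenethyl in place of furan-3-yl on a saturated chain carbon bound to a nitrogen on an aromatic ring).

Two measured steps come closest to this change (a step that the two limits leave unreadable from compound 1 to compound 3 and a step that the two limits leave unreadable from compound 2 to compound 3), and neither has a size that can be carried over. No clear change is therefore expected, in either direction, and the most likely result is another limit. The estimated step is small (a step that the limit leaves unreadable from compound 3 to compound 4) and stays near that limit. Compound 4 is estimated at 15000 nM in this assay, with an expected range from 5000 nM to 30000 nM as its upper end.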

Compound 4, half-maximal cytotoxic concentration: > 10000 nM
Compound 4: a limit, no number; the forecaster's own chance of this, stated with the estimate: 80%; the middle value does not contradict the limit.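

In this assay compound 4 gives > 10000 nM, a limit of the assay and not a number. Its steps from compound 1, compound 2 and compound 3 therefore cannot be read: the limit of > 10000 nM in this assay, at which 4 of the 4 values shown sit.

The compounds shown leave open whether any of these four groups changes how much compound the cells tolerate.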